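Neopentyl in place of cyclohexyl: expected agonist potency

This account rests on a few compounds, and the source may have more. Where it says the series, first, only, none or still open, it means among the compounds named here.

Among the compounds with values here, compound 1 `O=C(O)c1ccccc1-c1ccc(CCc2ncc(CC3CCCCC3)[nH]2)cc1` gives 41 nM in an in vitro functional assay on cells for agonist activity at Bombesin receptor subtype-3 (Homo sapiens), read by luminescence and calcium flux (a higher number here means that more compound is needed for the effect, a lower number that less compound is needed), the lowest of the two numbers measured so far. Compound 2 `O=C(O)c1ccccc1-c1ccc(CCc2ncc(Cc3ccc(Cl)cc3)[nH]2)cc1` gives 2290 nM; the step of a 56-fold higher number from compound 1 to compound 2 (1.75 log units; beyond the scatter) comes with an aromatic ring in place of the cyclohexyl. Compound 3 `CC(C)(C)CCc1cnc(CCc2ccc(-c3ccccc3C(=O)O)cc2)[nH]1` differs from compound 1 by neopentyl in place of cyclohexyl on a saturated chain carbon bound to an aromatic carbon. Within the data shown here, only that one measured step is known, and it concerns an aromatic group, so it bears on this change loosely at most; compound 3 keeps a saturated, branched group. A small step, if any beyond the scatter, is expected, a 2.0-fold higher number from compound 1 to compound 3 (0.29 log units; within the scatter). Compound 3 is expected near 80 nM, within 25 nM to 300 nM.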

Compound 3, half-maximal effective concentration: 39 nM
Estimate against measurement, compound 3: 2.1-fold (0.31 log units) above; the range from low to high includes it.
By their numbers in this assay, from the lowest: compounds 3 and 1 (each within the scatter of the next); then compound 2.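

Neopentyl in place of cyclohexyl on a saturated chain carbon bound to an aromatic carbon gives a 1.1-fold lower number from compound 1 to compound 3 (0.02 log units; within the scatter) in this assay and so shows that a ring is not required in this group for the low number of compound 1. The open chain also stands apart from the aromatic group, with a 59-fold lower number from compound 2 to compound 3 (1.77 log units; beyond the scatter) for the same place, so the high number of compound 2 is not specific to the comparison with cyclohexyl. No measurement at hand explains either step.

Still open, as far as these compounds go, is whether the high number of compound 2 follows from the aromatic ring or from its chlorine, which unsubstituted phenyl would separate. Also open, from the compounds shown here alone, is how a shorter chain such as ethyl, or an amine on the chain, would read here.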